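The source may hold more compounds than are shown below. What is called first, only, known or untested is meant among the compounds shown, and "the series" means these compounds.

Of the compounds shown here, three have so far been measured in a functional assay on PC-3 cells (Homo sapiens) for inhibition, read by sulforhodamine B assay, with a stated time of 48 h; on this read-out lower numbers stand for stronger inhibition of growth and higher numbers for weaker inhibition of growth. Compound 1 `N#C/C(=C\c1c(-c2ccccc2)[nH]c2ccccc12)C(=O)c1ccccc1` gives 3500 nM, compound 3 `COc1ccc2[nH]c(-c3ccccc3)c(C=C(C#N)C#N)c2c1` gives 5400 nM, and compound 2 `COc1ccc(-c2[nH]c3ccc(OC)cc3c2/C=C(\C#N)S(=O)(=O)c2ccccc2)cc1` gives 534 nM, the lowest of the three numbers. Its distance to compound 1 and its distance to compound 3 both lie beyond the usual scatter, so compound 2 is the most potent of the three. Compound 4 `COc1ccc(-c2[nH]c3ccccc3c2/C=C(\C#N)S(=O)(=O)c2ccccc2)cc1` is derived from compound 2 by a single change: hydrogen in place of methoxy on an aromatic carbon. Among the measured compounds shown here, no measured pair shows this change, so its size in this assay is not known from the data. A small loss is expected, with a step estimated at a 1.5-fold higher number from compound 2 to compound 4 (0.18 log units; within the scatter). Compound 4 is therefore expected to give about 800 nM, within a range of 300 nM to 2500 nM.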

Compound 4, concentration for 50% growth inhibition: 557 nM
Compound 4: the middle estimate sits 1.4-fold (0.16 log units) above what was measured; measured number inside the range.
By their numbers in this assay, from the lowest: compounds 2 and 4 (each within the scatter of the next); then compounds 1 and 3 (each within the scatter of the next).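

In this assay, hydrogen in place of methoxy on an aromatic carbon of the six-membered ring of carbon only gives a 1.0-fold higher number from compound 2 to compound 4 (0.02 log units; within the scatter). Among the compounds shown here, at this position, then, the methoxy group can be lost without a detectable change in growth inhibition, which the earlier compounds could not show. No available measurement explains this result. The compounds shown carry only methoxy or hydrogen at this carbon, so the effect of an amine, a carboxylic acid or a longer chain such as butoxy there remains open.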